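The compounds below may be only part of what the source reports. "The series", "measured", "known", "first", "only" and "open" are said of these compounds alone.

Among the measured compounds shown here, in an in vitro functional assay on cells for agonist activity at Bombesin receptor subtype-3 (Homo sapiens), read by luminescence and calcium flux (on this read-out lower numbers stand for an effect already at smaller amounts and higher numbers for an effect only at larger amounts of compound), compound 2 `O=C(O)c1ccccc1-c1ccc(CCc2ncc(Cc3ccccc3Cl)[nH]2)cc1` gives 292 nM, the only number among the two values shown. Compound 1 `CCCCc1cnc(Cc2ccc(-c3ccccc3C(=O)O)cc2)[nH]1` reaches only the limit of the assay, at > 10000 nM; that limit is the limit of > 10000 nM in this assay, at which 1 of the 2 values shown sits, and it is a limit, not a measured number. For the measured compounds named here, no step between compounds that differ in one place is available, so nothing beyond the two values themselves can be said of compounds 1 and 2.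

Compound 3 `CCC(C)(CC)Cc1cnc(CCc2ccc(-c3ccccc3C(=O)O)cc2)[nH]1` remains to be measured in this assay. It differs from compound 2 by 1-ethyl-1-methylpropyl in place of 2-chlorophenyl on a saturated chain carbon bound to an aromatic carbon. Going by the values given here, with no measured step to lean on, the expectation for the step from compound 2 to compound 3, an 8.6-fold higher number from compound 2 to compound 3 (0.93 log units; beyond the scatter), is a weakening that goes beyond the usual scatter of repeated measurements. Compound 3 is therefore estimated at 2500 nM, in a range from 500 nM to 10000 nM.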

Compound 3, half-maximal effective concentration: 76 nM
Compound 3: the middle estimate sits 33-fold (1.52 log units) above what was measured, and the stated range ends above it.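

At the position on a saturated chain carbon bound to an aromatic carbon, this assay shows that 2-chlorophenyl is not needed for activity: putting 1-ethyl-1-methylpropyl, a group with no ring, in its place gives a 3.8-fold lower number from compound 2 to compound 3 (0.58 log units; beyond the scatter). Among the compounds shown here, this is the first reading of a change between compounds that differ in one place, and it describes this single pair, not a trend. Nothing measured here explains why the group without a ring gives the lower number.

This one step does not separate the loss of the ring and the chlorine from the arrival of the branched chain. An unbranched hexyl chain, a cyclohexyl ring or a plain phenyl at the same place remains to be compared before either can be credited.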